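Anilinoquinazoline Sulfonamides: Thiourea Linker and Aniline Swap

The source may report more compounds than this note shows. Statements on the series, on what has been measured and on what is new or still open speak of the compounds shown alone.

Measured compounds:
Compound 1, `COc1cc2ncnc(Nc3ccc(Cl)c(C(F)(F)F)c3)c2cc1OCCCCC(=O)Nc1ccc(S(N)(=O)=O)cc1`: 9270 nM
Compound 2, `NS(=O)(=O)c1ccc(NC(=S)Nc2ccc3ncnc(Nc4ccc(F)c(Br)c4)c3c2)cc1`: > 40000 nM

Of the compounds shown here, two have been measured in a functional assay on A549 cells (Homo sapiens) for antiproliferative activity, read by MTT assay, with a stated time of 72 h; on this read-out higher numbers stand for weaker inhibition and lower numbers for stronger inhibition. Compound 1 gives 9270 nM. For compound 2 only a limit is known, > 40000 nM, and it therefore stands at the limit of > 40000 nM in this assay, at which 1 of the 2 values shown sits, rather than at a number. Within the data shown here, compound 1 and compound 2 differ in the linker to the sulfonamide-bearing aniline and in the aniline on the shared core, so no single step between them can be read.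

The step to be followed leads from compound 2 to compound 3, `NS(=O)(=O)c1ccc(NC(=S)Nc2ccc3ncnc(Nc4cccc(Cl)c4)c3c2)cc1`. The change is 3-chlorophenyl in place of 3-bromo-4-fluorophenyl on a nitrogen on an aromatic ring. The thiourea linker and the sulfonamide remain unchanged. Among the measured compounds shown here, since compound 2 has given only a limit in this assay, no measured step in this set tells how a change on this aniline shifts potency, and the shared thiourea scaffold has so far produced no number at all.

Compound 3 is therefore expected to stay near the limit, with the step from compound 2 to compound 3 estimated as a number no higher from compound 2 to compound 3 (the limit leaves the size open), none beyond the scatter. For compound 3 the estimated value is 40000 nM, with a range from 12000 nM to 130000 nM.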

Compound 3, half-maximal inhibitory concentration: > 40000 nM
Compound 3: only a limit was reported; the forecaster's own chance of this, stated with the estimate: 60%; the middle value sits exactly at the limit.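

Among these compounds, compound 2 and compound 3 both stand at a limit rather than at a number in this assay, so no step between them can be read. The compounds shown leave open whether any aniline on the shared thiourea scaffold gives a number in this assay, and how far a change on that aniline shifts potency.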